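Replacing a phenyl with naphthalen-1-yl on a shared core

A few compounds are considered here, and "the series" means these few. Any claim that something is new, unique, unknown or untested is made for them only; others in the source may bear on it.

Of the compounds shown here, three sharing one core have been measured in a functional assay on HT-29 cells (Homo sapiens) for inhibition, read by MTT assay, with a stated time of 48 h; on this read-out higher numbers stand for weaker inhibition and lower numbers for stronger inhibition. Compound 1 `COc1cc(-c2cc(-c3ccc(Br)cc3)nc(-c3ccccc3)n2)cc(OC)c1OC`, which carries a 4-bromophenyl group, gives 3170 nM. Compound 2 `COc1cc(-c2cc(-c3cccc([N+](=O)[O-])c3)nc(-c3ccccc3)n2)cc(OC)c1OC`, which carries a 3-nitrophenyl group, gives > 25000 nM, and this is a limit of the assay rather than a number. Compound 3 `COc1cc(-c2cc(-c3ccccc3)nc(-c3ccccc3)n2)cc(OC)c1OC`, with a plain phenyl group in that place, gives 7930 nM, the higher of the two actual numbers.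

Going by the values given here, compound 4 `COc1cc(-c2cc(-c3cccc4ccccc34)nc(-c3ccccc3)n2)cc(OC)c1OC` changes only that group of compound 3: naphthalen-1-yl in place of phenyl on an aromatic carbon. In words, naphthalen-1-yl stands in place of phenyl on an aromatic carbon.

The measured steps all concern this same group, and they point in different directions. Removing the bromo gives a 2.5-fold higher number from compound 1 to compound 3 (0.40 log units; beyond the scatter), whereas removing the nitro gives an at least 3.1-fold lower number from compound 2 to compound 3 (0.49 log units; beyond the scatter). Between the two substituted compounds lies an at least 7.8-fold higher number from compound 1 to compound 2 (0.89 log units; beyond the scatter). Extra atoms on the phenyl have therefore helped in one case and hurt in the other, and neither substituent resembles a second fused ring. Among the compounds with values here, compound 1 is the only guide toward stronger inhibition, with its 3170 nM, so only a modest gain is expected, with wide uncertainty.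

The expected change is a 1.6-fold lower number from compound 3 to compound 4 (0.20 log units; within the scatter). For compound 4 the estimated value is 5000 nM, with an expected range from 1500 nM to 18000 nM.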

Compound 4, half-maximal inhibitory concentration: 4730 nM
Estimate against measurement, compound 4: 1.1-fold (0.02 log units) above; measured number inside the range.
By their numbers in this assay, from the lowest: compounds 1, 4 and 3 (each within the scatter of the next, the first and the last beyond it). At a limit, above all of these: compound 2.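

Naphthalen-1-yl brings a second aromatic ring of carbon only and no hydrogen-bond donors or acceptors, and in this assay the step from the plain phenyl group is a 1.7-fold lower number from compound 3 to compound 4 (0.22 log units; within the scatter), so this much larger group is accepted at this position without a clear gain or loss. The step from the 4-bromophenyl group is a 1.5-fold higher number from compound 1 to compound 4 (0.17 log units; within the scatter), so compound 4 cannot be told apart from compound 1 either, even though compound 1 and compound 3 do differ beyond the scatter, and group size alone therefore does not sort these compounds, with compound 2 as the clear exception among the substituted groups. The step from the 3-nitrophenyl group is an at least 5.2-fold lower number from compound 2 to compound 4 (0.72 log units; beyond the scatter), which gives only a bound since compound 2 sits at a limit and not at a number: the limit of > 25000 nM in this assay, at which 1 of the 4 values shown sits.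

The compounds shown leave open whether naphthalen-2-yl, attached through the other ring carbon, would read like naphthalen-1-yl. They also leave open how an amine or a carboxylic acid would behave on the phenyl ring, and whether 3-bromophenyl or 4-nitrophenyl would separate the effect of the group from the effect of its place on the ring.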